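The compounds below may be only part of what the source reports. "The series", "measured", "known", "first", "only" and "open" are said of these compounds alone.

In a functional assay on a cell-free system (plasma, Oryctolagus cuniculus) for inhibition, with stated times of 5 min, 1 min and 6 min (on this read-out higher numbers stand for weaker inhibition and lower numbers for stronger inhibition), compound 1 `CCOCCOn1c(-c2cccc(C#N)c2)nc(C)c1C(=O)OCC` gives 6250 nM and compound 2 `CCOC(=O)c1c(C)nc(-c2cccc(C#N)c2)n1OCc1ccccc1F` gives 8990 nM, so these two values lie within the scatter of each other. Compound 3 `CCOC(=O)c1c(C)nc(-c2cccc(C#N)c2)n1OCc1cccc(F)c1` has 3-fluorophenyl in place of the 2-fluorophenyl of compound 2, on a saturated chain carbon bound to an oxygen on an aromatic ring: 3-fluorophenyl in place of 2-fluorophenyl on a saturated chain carbon bound to an oxygen on an aromatic ring. For the measured compounds named here, the one measured step at this place is a 1.4-fold higher number from compound 1 to compound 2 (0.16 log units; within the scatter), and no measured pair tests this exact swap. In this assay, the expected change is therefore a 1.1-fold lower number from compound 2 to compound 3 (0.05 log units; within the scatter), nothing beyond the scatter. For compound 3 the estimate is 8000 nM, with an expected range of 3500 nM to 18000 nM.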

Compound 3, half-maximal inhibitory concentration: 22400 nM
Estimate against measurement, compound 3: 2.8-fold (0.45 log units) below; measured number outside the range, above it.
By their numbers in this assay, from the lowest: compounds 1 and 2 (each within the scatter of the next); then compound 3.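

In this assay the placement of the fluorine counts: swapping 2-fluorophenyl for 3-fluorophenyl gives a 2.5-fold higher number from compound 2 to compound 3 (0.40 log units; beyond the scatter) even though both compounds hold the same atoms. The 3-fluorophenyl group also separates from ethoxymethyl, with a 3.6-fold higher number from compound 1 to compound 3 (0.55 log units; beyond the scatter) as the weaker result, whereas 2-fluorophenyl stayed within the scatter of ethoxymethyl. Nothing available explains this difference.

Still open, going by these compounds, is how a plain phenyl group without fluorine would compare at this place. A chlorine or a methoxy group in place of the fluorine also remains to be placed against these values.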